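This account rests on a few compounds, and the source may have more. Where it says the series, first, only, none or still open, it means among the compounds named here.

Measured compounds:
compound 1, `COc1cc(NC(=O)c2cncc(N3CC4CC(C3)N4)c2)cc(OC)c1`: 0.985 nM
compound 2, `O=C(Nc1ccccc1F)c1cncc(N2CC3CC(C2)N3)c1`: 0.315 nM

Both numbers come from an assay on membranes from Cerebral cortex for displacement of a labelled ligand from Neuronal acetylcholine receptor; alpha4/beta2 (Rattus norvegicus); on this read-out higher numbers stand for weaker inhibition and lower numbers for stronger inhibition. Compound 2 holds the lowest number of the two; the nearest compound is compound 1, whose number is higher by a gap beyond the scatter. The two compounds differ in more than one place, so that gap cannot be assigned to a single change; only the two values themselves are known.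

Compound 3, `O=C(Nc1cccc(Cl)c1)c1cncc(N2CC3CC(C2)N3)c1`, has not been measured. It differs from compound 2 as follows: 3-chlorophenyl in place of 2-fluorophenyl on an amide-type nitrogen. This is a halogen-for-halogen exchange on the aromatic ring carried by the amide-type nitrogen, with a shift in where the halogen sits on that ring.

Among the compounds with values here, no step between measured compounds that differ in one place exists, so nothing anchors the size of this move in this assay . The expectation is a small step toward a somewhat higher number, within or only just beyond the scatter, since compound 2 at 0.315 nM already sits low. The expected step from compound 2 to compound 3 is a 1.7-fold higher number from compound 2 to compound 3 (0.24 log units; within the scatter). Compound 3 is accordingly estimated at 0.55 nM, in a range from 0.15 nM to 2 nM.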

Compound 3, inhibition constant: 0.042 nM
For compound 3 the middle estimate is 13-fold (1.12 log units) above the measured one, and the stated range ends above it.
By their numbers in this assay, from the lowest: compound 3; then compound 2; then compound 1.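

In this assay, the aryl group on the amide-type nitrogen proves to be a sensitive place: 3-chlorophenyl in place of 2-fluorophenyl gives a 7.5-fold lower number from compound 2 to compound 3 (0.88 log units; beyond the scatter). Within the data shown here, this is the first step that can be read at a single place, and it shows that the number can move beyond the scatter even though the leaving and entering groups match in heavy-atom count, aromatic ring, hydrogen-bond donors and acceptors, and net charge; they differ only in the halogen and where it sits on the ring. No measurement shown here accounts for the size of this step.

The step changes the halogen and its place on the ring together, so the share of each in the lower number remains unresolved. Also open, going by these compounds, is how far this place tolerates other groups, such as an unsubstituted phenyl ring, a bromine, a nitrile, an amine or a carboxylic acid on that ring, and whether the step would hold on a different core.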